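Two Diaminopyrazine Analogues and an Untested Aryl Variant

The source may report more compounds than this note shows. Statements on the series, on what has been measured and on what is new or still open speak of the compounds shown alone.

Measured compounds:
compound 1, `CCOc1cccc(Nc2nc3nonc3nc2Nc2cccc(OCC)c2)c1`, 10100 nM
compound 2, `Fc1ccccc1Nc1nc2nonc2nc1NC1CCCCC1`, 13400 nM

In an assay on mitochondria from L6 cells (Rattus norvegicus) for activation, with a stated time of 90 min (a lower number here means that less compound is needed, a higher number that more compound is needed for the effect), compound 2 and compound 1 give numbers that lie within the scatter of each other, so nothing separates them. Compound 3, `Oc1ccc(F)c(Nc2nc3nonc3nc2Nc2ccccc2F)c1`, has not been measured. It differs from compound 2 in one place: 2-fluoro-5-hydroxyphenyl in place of cyclohexyl on a nitrogen on an aromatic ring. Compound 1, which carries an aryl group on both of its nitrogens, gives 10100 nM, and on that basis the step of a 1.5-fold lower number from compound 2 to compound 3 (0.17 log units; within the scatter) is expected to stay within the scatter. Compound 3 is therefore estimated at 9000 nM, with a range from 2500 nM to 30000 nM.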

Compound 3, half-maximal effective concentration: 30000 nM
Compound 3: the middle estimate sits 3.3-fold (0.52 log units) below what was measured; the range from low to high includes it.
By their numbers in this assay, from the lowest: compounds 1 and 2 (each within the scatter of the next); then compound 3.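

In this assay 2-fluoro-5-hydroxyphenyl in place of cyclohexyl on a nitrogen on an aromatic ring goes with a 2.2-fold higher number from compound 2 to compound 3 (0.35 log units; beyond the scatter) and this modest step lies beyond the scatter. The earlier compounds shown here offered no step that differed in one place, so this is the only direct sign that the number responds to the group on this nitrogen. Nothing measured here accounts for the step. Still open, from the compounds shown here alone, is whether the hydroxyl or the fluorine of the entering group matters, and how an unsubstituted phenyl or a piperidine ring would fare on this nitrogen.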